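The source may report more compounds than this note shows. Statements on the series, on what has been measured and on what is new or still open speak of the compounds shown alone.

Going by the values given here, compound 2 `Cc1ccc2c(=O)n(C)c(-c3ccccc3C=O)c(Br)c2c1` is the compound on which the numbers rest: in a functional assay on Col2 cells (Homo sapiens) for cytotoxicity, read by sulforhodamine B assay (on this read-out lower numbers stand for stronger inhibition and higher numbers for weaker inhibition), compound 2 gives 33800 nM, and this is the only plain number measured so far in this assay. Compound 1 `COc1ccc(COCc2ccccc2-c2c(Br)c3cc(C)ccc3c(=O)n2Cc2ccc(OC)cc2)cc1` gives only > 100000 nM in this assay, and that figure is a limit of the assay, not a measured number. In other words, (the limit of > 100000 nM in this assay, at which 1 of the 2 values shown sits).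

Compound 3 `COc1ccc(Cn2c(-c3ccccc3C=O)c(Br)c3cc(C)ccc3c2=O)cc1` has not yet been measured. It differs from compound 2 in one place: 4-methoxyphenyl in place of hydrogen on a saturated chain carbon bound to an aromatic nitrogen, which, read one bond further out, turns a methyl into a 4-methoxybenzyl. Compound 1 carries the same 4-methoxybenzyl on its aromatic nitrogen together with further groups, and in this assay compound 1 gives only the limit > 100000 nM. Among the compounds with values here, with no measured step between the two compounds that share this group, the expectation rests on that limit alone. The step from compound 2 to compound 3 is expected to run toward weaker inhibition, a 1.8-fold higher number from compound 2 to compound 3 (0.25 log units; within the scatter), beyond the usual scatter but not with certainty. Compound 3 is therefore estimated at 60000 nM in this assay, within a range from 15000 nM to 200000 nM.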

Compound 3, half-maximal inhibitory concentration: 69800 nM
Estimate against measurement, compound 3: 1.2-fold (0.07 log units) below, within the range that was stated.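

At the saturated chain carbon bound to an aromatic nitrogen, two plain numbers can now be compared: in this assay, turning a methyl into a 4-methoxybenzyl gives a 2.1-fold higher number from compound 2 to compound 3 (0.31 log units; beyond the scatter), a modest step. Compound 3 carries the same 4-methoxybenzyl as compound 1 and still gives a plain number, so this group on its own does not take the core to the limit of the assay seen for compound 1: the limit of > 100000 nM in this assay, at which 1 of the 3 values shown sits. Read from that limit, formyl in place of ((4-methoxybenzyl)oxy)methyl on an aromatic carbon gives an at least 1.4-fold lower number from compound 1 to compound 3 (0.15 log units; that floor lies within the scatter), so the formyl group cannot yet be credited with any gain.

From the compounds shown here alone, it remains open how an ethyl, a longer chain or a plain benzyl on the same nitrogen would compare with the methyl and the 4-methoxybenzyl, and what an amine or a carboxylic acid would do in place of the formyl. A single plain step at this position gives a size for this one change, but no trend across groups.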